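The source may hold more compounds than are shown below. What is called first, only, known or untested is meant among the compounds shown, and "the series" means these compounds.

Compound 3 `COc1ccc(/C=C/C(=O)Nc2cc(C(=O)c3cc(OC)c(OC)c(OC)c3)cc(OC)c2OC)cc1` was tested in a functional assay on PC-3 cells (Homo sapiens) for cytotoxicity, read by MTT assay, with a stated time of 72 h (a lower number here means a stronger inhibitor, a higher number a weaker inhibitor), where compound 3 gives 6300 nM. Among the three numbers at hand this is the second highest; its nearest neighbour is compound 2 `COc1cccc(/C=C/C(=O)Nc2cc(C(=O)c3cc(OC)c(OC)c(OC)c3)ccc2OC)c1`, which in this assay gives 4700 nM, and the furthest is compound 1 `COc1ccc(/C=C/C(=O)Nc2cc(C(=O)c3cc(OC)c(OC)c(OC)c3)ccc2OC)cc1`, which in this assay gives 11100 nM, both gaps lying within the scatter. Compound 4 `COc1cc(C(=O)c2cc(OC)c(OC)c(OC)c2)cc(NC(=O)/C=C/c2ccc(F)cc2)c1OC` differs from compound 3 by fluoro in place of methoxy on an aromatic carbon. Within the data shown here, no measured step exchanges a methoxy for a fluoro, so the expectation rests on steps that touch neighbouring parts of the molecule. Placing 3-methoxyphenyl instead of 4-methoxyphenyl gave a 2.4-fold lower number from compound 1 to compound 2 (0.37 log units; beyond the scatter), while adding a methoxy on the shared core gave a 1.8-fold lower number from compound 1 to compound 3 (0.25 log units; within the scatter). Among the measured compounds shown here, only one of these steps reaches beyond the scatter, and it is modest. On this basis a step in this assay of about a 1.1-fold lower number from compound 3 to compound 4 (0.06 log units; within the scatter) is expected, with no direction that can be trusted beyond the scatter. Compound 4 is therefore estimated at 5500 nM in this assay, within a range from 2000 nM to 15000 nM.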

Compound 4, half-maximal inhibitory concentration: 4100 nM
Estimate against measurement, compound 4: 1.3-fold (0.13 log units) above; the range from low to high includes it.
By their numbers in this assay, from the lowest: compounds 4, 2, 3 and 1 (each within the scatter of the next, the first and the last beyond it).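

In this assay, among these compounds, the exchange of 4-methoxyphenyl for 4-fluorophenyl gave a 1.5-fold lower number from compound 3 to compound 4 (0.19 log units; within the scatter), the first reading in which the methoxy at this place is replaced rather than moved or joined by another methoxy on the shared core. At this carbon, para to a large group, the methoxy can therefore give way to fluoro without a change that stands clear of the scatter in this assay. No measurement at hand accounts for the size of this step.

As far as these compounds go, whether an amine or a carboxylic acid at this same carbon would shift the number beyond the scatter remains open. Also open, from the compounds shown here alone, is whether the exchange of methoxy for fluoro would give a step of similar size on the core of compound 1, which lacks the added methoxy.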